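The source may hold more compounds than are shown below. What is called first, only, known or untested is meant among the compounds shown, and "the series" means these compounds.

Three compounds have numbers in an assay on isolated protein for inhibition of sulfide:quinone oxidoreductase, mitochondrial (Homo sapiens) (a lower number here means a stronger inhibitor, a higher number a weaker inhibitor), so far. Compound 1 `COc1ccc(-c2cc(-c3ccc(F)cc3)c(C#N)c(OC)n2)cc1` gives 1360 nM in this assay, compound 2 `COc1nc(-c2ccccc2)cc(-c2ccc(Cl)cc2)c1C#N` gives 252 nM, and compound 3 `COc1nc(-c2ccccn2)cc(C(C)(C)C)c1C#N` gives 850 nM. Compound 2 therefore shows the lowest number of the three; its nearest neighbour is compound 3 and its furthest is compound 1, and both gaps lie beyond the scatter. Compound 4 `COc1nc(-c2ccccc2)cc(-c2ccncc2)c1C#N` has not yet been measured in this assay. It differs from compound 2 by pyridin-4-yl in place of 4-chlorophenyl on an aromatic carbon on the shared core. For the measured compounds named here, with no measured step of this kind to lean on, the step from compound 2 to compound 4 is expected to raise the number moderately, beyond the scatter, as a 3.2-fold higher number from compound 2 to compound 4 (0.50 log units; beyond the scatter). Compound 4 is thus estimated at 800 nM in this assay, within a range from 250 nM to 2500 nM.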

Compound 4, half-maximal inhibitory concentration: 541 nM
The estimate for compound 4 lay 1.5-fold (0.17 log units) above the measured number; measured number inside the range.
By their numbers in this assay, from the lowest: compound 2; then compounds 4, 3 and 1 (each within the scatter of the next, the first and the last beyond it).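

In this assay pyridin-4-yl in place of 4-chlorophenyl, on the aromatic carbon opposite the ring nitrogen, gives a 2.1-fold higher number from compound 2 to compound 4 (0.33 log units; beyond the scatter) as the first step read at this position. The number moves only modestly across this exchange of one six-membered aromatic ring for another, so a ring nitrogen is accepted here with a limited loss. No measurement on hand accounts for the step.

The compounds shown leave open whether the chlorine or the ring nitrogen drives this step. From the compounds shown here alone, how an amine or a carboxylic acid would fare at this position also remains open.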